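From 2,4,5-trichlorophenyl to 2-chlorophenyl

The source may hold more compounds than are shown below. What is called first, only, known or untested is meant among the compounds shown, and "the series" means these compounds.

Measured in a functional assay on HepG2 cells (Homo sapiens) for antiproliferative activity, read by MTT assay, with a stated time of 72 h; a lower number here means a stronger inhibitor, a higher number a weaker inhibitor:
- Compound 1 `NC1=NC2(CCSCC2)N(OCCCOc2ccc(Cl)c(Cl)c2)C(N)=N1`: 70 nM
- Compound 2 `NC1=NC2(CCSCC2)N(OCCCOc2cccc(Cl)c2Cl)C(N)=N1`: 50 nM
- Compound 3 `NC1=NC2(CCSCC2)N(OCCCOc2cc(Cl)c(Cl)cc2Cl)C(N)=N1`: > 100000 nM

Compound 3 stands at > 100000 nM, which is a limit of the assay and not a number. Compound 4 `NC1=NC2(CCSCC2)N(OCCCOc2ccccc2Cl)C(N)=N1`, not yet measured, carries 2-chlorophenyl in place of 2,4,5-trichlorophenyl on an oxygen on a saturated carbon.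

Two measured steps lead into compound 3, and both are large: an at least 1400-fold higher number from compound 1 to compound 3 (3.15 log units; beyond the scatter) and an at least 2000-fold higher number from compound 2 to compound 3 (3.30 log units; beyond the scatter). Moving chlorines between the two dichlorophenyl compounds matters far less: a 1.4-fold lower number from compound 1 to compound 2 (0.15 log units; within the scatter), which is within the scatter. For the measured compounds named here, no measured compound carries a single chlorine, so the reasoning stretches here and the range must stay wide. Still, the large steps are expected to run in reverse in this assay, towards the level of compound 2 at 50 nM. The estimated step is an at least 500-fold lower number from compound 3 to compound 4 (2.69 log units; beyond the scatter), a large fall in the number. Compound 4 is estimated at 200 nM, with an expected range from 30 nM to 5000 nM.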

Compound 4, half-maximal inhibitory concentration: 80 nM
Compound 4: middle estimate off by 2.5-fold (0.40 log units), on the high side, within the range that was stated.
By their numbers in this assay, from the lowest: compounds 2, 1 and 4 (each within the scatter of the next). At a limit, above all of these: compound 3.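

Compound 3 stands at > 100000 nM, which is a limit of the assay and not a number. In this assay, for the compounds shown here, 2-chlorophenyl in place of 2,4,5-trichlorophenyl gives an at least 1200-fold lower number from compound 3 to compound 4 (3.09 log units; beyond the scatter), while a 1.6-fold higher number from compound 2 to compound 4 (0.20 log units; within the scatter) and a 1.1-fold higher number from compound 1 to compound 4 (0.06 log units; within the scatter) show that the single chlorine of compound 4 does as well as either pair of chlorines, so the loss belongs to the 2,4,5-trichlorophenyl group alone and not to chlorine on this ring in general. Adding one chlorine therefore has no fixed effect at this position, and the outcome depends on the ring that receives it: the same change on two cores in this assay, an at least 1400-fold higher number (3.15 log units; beyond the scatter) from compound 1 to compound 3 and a 1.6-fold lower number (0.20 log units; within the scatter) from compound 4 to compound 2, at least 2200-fold (3.35 log units) apart, beyond the scatter of two such steps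

Going by these compounds alone, compound 3 is the only compound here with three chlorines, so it remains open whether their number or their arrangement decides the outcome. As far as these compounds go, how a methoxy group or a nitrile on this phenyl ring would behave also remains open.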